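Amino in place of hydroxy on compound 2

The source may report more compounds than this note shows. Statements on the series, on what has been measured and on what is new or still open speak of the compounds shown alone.

Measured so far (a functional assay on A549 cells (Homo sapiens) for antiproliferative activity, read by MTT assay, with a stated time of 48 h; a higher number here means a weaker inhibitor, a lower number a stronger inhibitor):
- compound 1 `COc1ccc(C(=O)c2ccc(OC)c3c2OC(C)(C)C=C3)c(NC(=O)CN(C)C)c1` (890 nM)
- compound 2 `C=C(c1cc(OC)c(OC)c(OC)c1)c1ccc(OC)cc1NC(=O)CO` (20 nM)

Compound 2 has the lower number of the two and therefore stands as the stronger inhibitor here. Its gap to compound 1 lies well beyond the usual scatter. The two compounds differ in more than one place, so that gap says nothing about any single group.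

Compound 3 `C=C(c1cc(OC)c(OC)c(OC)c1)c1ccc(OC)cc1NC(=O)CN` keeps everything in compound 2 except one group, carrying amino in place of hydroxy on a saturated chain carbon bound to a carbonyl carbon and unmeasured so far. Among the compounds with values here, no measured pair shows this exchange, so the expectation rests only on compound 2 at (20 nM) and on the small size of the change. In this assay no step beyond the scatter is expected in either direction, though a modest loss would not surprise. The expected 1.3-fold higher number from compound 2 to compound 3 (0.10 log units; within the scatter) is therefore small. For compound 3 the estimated value is 25 nM, with an expected range from 6 nM to 110 nM.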

Compound 3, half-maximal inhibitory concentration: 40 nM
The estimate for compound 3 lay 1.6-fold (0.20 log units) below the measured number; measured number inside the range.
By their numbers in this assay, from the lowest: compounds 2 and 3 (each within the scatter of the next); then compound 1.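

In this assay, amino in place of hydroxy on a saturated chain carbon bound to a carbonyl carbon gives a 2.0-fold higher number from compound 2 to compound 3 (0.30 log units; within the scatter). Within the data shown here, this is the first single-place step, and it shows that this position accepts either group with no difference that can be told from the scatter, which the multi-place gap to compound 1 could not show. The two groups have the same counts of heavy atoms, hydrogen-bond donors and hydrogen-bond acceptors, and neither carries a net charge, so the step reports on an oxygen-to-nitrogen exchange alone, and no measured evidence bears on it.

One step at this position cannot show how far the position's acceptance extends: a carboxylic acid, a fluorine or a longer chain on the same saturated carbon would each test it beyond this matched exchange. On these data alone, it also remains open whether hydroxy and amino would stay within the scatter of each other on a different core, such as that of compound 1, since the exchange is seen here only on the core shared by compound 2 and compound 3.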